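The compounds below may be only part of what the source reports. "The series", "measured", "known", "first", "only" and "open" are said of these compounds alone.

The series turns on one structural change made twice on two related cores. Compound 1 `C=CC(=O)Nc1cc(Nc2ncc3ncn(-c4ccc(C(C)C)cc4)c3n2)c(OC)cc1N(C)CCN(C)C` and compound 2 `C=CC(=O)Nc1cc(Nc2ncc3ncn(-c4ccc(I)cc4)c3n2)c(OC)cc1N(C)CCN(C)C` share one core, and compound 3 `C=CC(=O)Nc1cc(Nc2ncc3[nH]c(=O)n(-c4ccc(C(C)C)cc4)c3n2)c(OC)cc1N1CCN(C)CC1` and compound 4 `C=CC(=O)Nc1cc(Nc2ncc3[nH]c(=O)n(-c4ccc(I)cc4)c3n2)c(OC)cc1N1CCN(C)CC1` share another; the difference between the two cores is not broken down here. All three measured compounds were tested in an ADME assay on HT-29 cells (Homo sapiens) for cytotoxicity, read by MTT assay, with a stated time of 72 h; a higher number here means a weaker inhibitor, a lower number a stronger inhibitor. Compound 1 gives 15300 nM, compound 2 gives 9520 nM, and compound 3 gives 14300 nM.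

The change from compound 1 to compound 2 is iodo in place of isopropyl on an aromatic carbon. Its effect in this assay is a 1.6-fold lower number from compound 1 to compound 2 (0.21 log units; within the scatter), so within this pair the iodo and isopropyl analogues cannot be told apart with confidence. Compound 3 sits close to compound 1 and compound 2, and all three numbers lie within the usual scatter of one another.

Compound 4 has not yet been measured. It differs from compound 3 by iodo in place of isopropyl on an aromatic carbon, the same change that separates compound 1 from compound 2, made at the same kind of place. Since that change in the first pair produced a 1.6-fold lower number from compound 1 to compound 2 (0.21 log units; within the scatter), a step of similar size and direction is expected here: compound 3 to compound 4 is estimated as a 1.5-fold lower number from compound 3 to compound 4 (0.18 log units; within the scatter). On that basis compound 4 is expected to give about 9500 nM in this assay, with the range 5000 nM to 18000 nM judged plausible given the scatter.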

Compound 4, half-maximal inhibitory concentration: 39300 nM
Compound 4: the middle estimate sits 4.1-fold (0.62 log units) below what was measured, and the stated range ends below it.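

In this assay, the exchange of isopropyl for iodo on an aromatic carbon did not carry over from one core to the other: the same change on two cores in this assay, a 1.6-fold lower number (0.21 log units; within the scatter) from compound 1 to compound 2 and a 2.7-fold higher number (0.44 log units; beyond the scatter) from compound 3 to compound 4, 4.4-fold (0.65 log units) apart, beyond the scatter of two such steps. On the core of compound 3 the change gives a 2.7-fold higher number from compound 3 to compound 4 (0.44 log units; beyond the scatter), a modest step that makes the iodo analogue the weaker inhibitor of that pair, whereas on the core of compound 1 the iodo and isopropyl analogues cannot be told apart with confidence. Among the compounds shown here, this shows that, in this series, the result of this change on one core was a poor guide to its result on the other, but with only one pair on each core it does not show why, and since the difference between the two cores is not broken down, the gap cannot be assigned to any one part of them.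

The compounds shown leave open whether chloro, bromo or methyl in place of isopropyl on the same aromatic carbon would also behave differently on the two cores. They also leave open which part of the difference between the cores goes with the gap, and whether the same gap would appear with other groups, such as a morpholine, on the core of compound 3.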